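This account rests on a few compounds, and the source may have more. Where it says the series, first, only, none or still open, it means among the compounds named here.

Going by the values given here, compound 2 `N#C[C@@H]1CCCN1C(=O)[C@@H]1C[C@H](C(N)=O)CN1` gives 20% in an assay on the whole organism (plasma, strain Sprague-Dawley) for inhibition of Dipeptidyl peptidase 4 (Rattus norvegicus), with a stated time of 10 h, at a dose of 1 mg/kg by the oral route (on this read-out higher numbers stand for more inhibition at the one dose given (going by the name of the read-out) and lower numbers for less inhibition), the lower of the two numbers measured so far. Compound 1 `CCN(C)C(=O)[C@H]1C[C@@H](C(=O)N2CCC[C@H]2C#N)N[C@H]1C`, which carries an ethyl(methyl)carbamoyl group on the core of compound 1, gives 79% in this assay. Compound 3 `CCN(C)C(=O)[C@@H]1CN[C@H](C(=O)N2CCC[C@H]2C#N)C1` is not yet measured; it differs from compound 2 by ethyl(methyl)amino in place of amino on a carbonyl carbon. Among the compounds with values here, no single-change step between measured compounds is known, so the expectation rests on the two values alone. Compound 3 is expected to show a step of a number 35 percentage points higher from compound 2 to compound 3 (beyond the scatter) in this assay, upward and beyond the scatter, and its estimated inhibition is 55%, within 30% to 80%.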

Compound 3, a percentage reported as inhibition, in the whole organism at one dose (the size of the read-out at that dose, not a potency): 34%
Compound 3: middle estimate off by 21 percentage points, on the high side; measured number inside the range.
By their numbers in this assay, from the lowest: compound 2; then compound 3; then compound 1.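

In this assay, ethyl(methyl)amino in place of amino on a carbonyl carbon brings a number 14 percentage points higher from compound 2 to compound 3 (beyond the scatter) and so adds only modestly on its own. Hydrogen in place of methyl on a saturated ring carbon brings a number 45 percentage points lower from compound 1 to compound 3 (beyond the scatter), showing that, with ethyl(methyl)carbamoyl present, this methyl site carries a large change. No measurement shown explains either step.

As far as these compounds go, it remains open whether an ethyl group on that ring carbon would match methyl, and how a carboxylic acid in place of the carbamoyl group would read.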